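Swapping trifluoromethyl for methylsulfanyl on a phenol core

This account rests on a few compounds, and the source may have more. Where it says the series, first, only, none or still open, it means among the compounds named here.

Compound 1, `N#Cc1cc(C(=O)N2CS(=O)(=O)c3ccccc32)cc(Cl)c1O`, gives > 100000 nM in an assay on tissue (RPTEC cells) for inhibition of solute carrier family 22 member 12 (Homo sapiens), read by scintillation counting, with stated times of 15 min and 2 h (a higher number here means a weaker inhibitor, a lower number a stronger inhibitor), which is a limit of the assay rather than a number.
Compound 2, `CSc1cc(C(=O)N2CS(=O)(=O)c3ccccc32)cc(C#N)c1O`, gives 7100 nM in this assay.
Compound 3, `O=C(c1cc(Cl)c(O)c(C(F)(F)F)c1)N1CS(=O)(=O)c2ccccc21`, gives 2600 nM in this assay.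

Compound 3 has the lowest number of the three, with compound 2 the nearest at a gap beyond the scatter; compound 1 sits at the assay limit (the limit of > 100000 nM in this assay, at which 1 of the 3 values shown sits). The unmeasured compound 4, `CSc1cc(C(=O)N2CS(=O)(=O)c3ccccc32)cc(Cl)c1O`, differs from compound 3 in one place: methylsulfanyl in place of trifluoromethyl on an aromatic carbon. For the measured compounds named here, no measured step makes exactly this exchange. Going by the values given here, two steps bear on it indirectly, each starting from compound 1: an at least 14-fold lower number from compound 1 to compound 2 (1.14 log units; beyond the scatter) and an at least 38-fold lower number from compound 1 to compound 3 (1.58 log units; beyond the scatter). Both methylsulfanyl and trifluoromethyl thus gave much lower numbers than the groups they replaced on the same core, and compound 4 carries the methylsulfanyl group where compound 3 carries trifluoromethyl, with chloro and hydroxy unchanged. Because compound 3 reached 2600 nM and compound 2 reached 7100 nM, compound 4 is expected to land between them, a step of a 1.3-fold higher number from compound 3 to compound 4 (0.13 log units; within the scatter) that is not expected to exceed the scatter. The estimate for compound 4 in this assay is 3500 nM, with a range from 900 nM to 14000 nM.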

Compound 4, half-maximal inhibitory concentration: 5700 nM
For compound 4 the middle estimate is 1.6-fold (0.21 log units) below the measured one, and the stated range covers the measured number.
By their numbers in this assay, from the lowest: compound 3; then compounds 4 and 2 (each within the scatter of the next). At a limit, above all of these: compound 1.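

In this assay, trifluoromethyl and methylsulfanyl can now be compared directly at this position, ortho to a hydroxy group, with chloro unchanged: the exchange gives a 2.2-fold higher number from compound 3 to compound 4 (0.34 log units; beyond the scatter). With methylsulfanyl held in place, chloro in place of cyano gives a 1.2-fold lower number from compound 2 to compound 4 (0.10 log units; within the scatter), so that exchange shows no clear difference in this pair. Methylsulfanyl in place of cyano gives an at least 17-fold lower number from compound 1 to compound 4 (1.24 log units; beyond the scatter), and the starting value there is a limit of the assay rather than a number: the limit of > 100000 nM in this assay, at which 1 of the 4 values shown sits.

On these data alone, whether an amine, a carboxylic acid or a longer chain such as ethylsulfanyl at this position would give a number lower than that of compound 3 stays open. Also open, as far as these compounds go, is whether trifluoromethyl would keep its edge over methylsulfanyl with cyano in place of chloro.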